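Replacing a chlorophenyl arm with a hydroxyethyl chain

This account rests on a few compounds, and the source may have more. Where it says the series, first, only, none or still open, it means among the compounds named here.

Of the compounds shown here, three built on a shared core have been tested in a functional assay on RAW264.7 cells (Mus musculus) for inhibition, read by Griess assay, with stated times of 2 h and 24 h; on this read-out lower numbers stand for stronger inhibition and higher numbers for weaker inhibition. Compound 1 `COc1ccc([C@@H]2C/C(=N\O)c3c(O)cc(OCc4cn(Cc5ccccc5F)nn4)cc3O2)cc1O` gives 5710 nM, compound 2 `CCCn1cc(COc2cc(O)c3c(c2)O[C@H](c2ccc(OC)c(O)c2)C/C3=N\O)nn1` gives 2340 nM, and compound 3 `COc1ccc([C@@H]2CC(=O)c3c(O)cc(OCc4cn(Cc5ccccc5Cl)nn4)cc3O2)cc1O` gives 6140 nM. Compound 3 has the highest number of the three, meaning the weakest inhibition on this read-out; its number lies within the scatter of that of compound 1 but beyond the scatter of that of compound 2.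

Compound 4 `COc1ccc([C@@H]2CC(=O)c3c(O)cc(OCc4cn(CCCO)nn4)cc3O2)cc1O` is not yet measured. Its change from compound 3 is 2-hydroxyethyl in place of 2-chlorophenyl on a saturated chain carbon bound to an aromatic nitrogen.

Among the measured compounds shown here, one measured step bears on this. The step of a 2.4-fold lower number from compound 1 to compound 2 (0.39 log units; beyond the scatter) swapped an aromatic ring for a short chain at the same kind of position. Compound 1 and compound 3 differ in more than one place, so the two values only show that both stand high together. Since compound 4 makes the same kind of move, a short chain entering in place of an aromatic ring at the saturated carbon bound to the aromatic nitrogen, a modest lowering of the number in this assay is expected, by about a 2.0-fold lower number from compound 3 to compound 4 (0.31 log units; beyond the scatter). Compound 4 is therefore estimated at 3000 nM, with a likely range from 1200 nM to 7500 nM.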

Compound 4, half-maximal inhibitory concentration: 16700 nM
Estimate against measurement, compound 4: 5.6-fold (0.75 log units) below; the measured number lies above the stated range.
By their numbers in this assay, from the lowest: compound 2; then compounds 1 and 3 (each within the scatter of the next); then compound 4.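

In this assay, putting a short chain in place of an aromatic ring on a saturated chain carbon bound to an aromatic nitrogen gives a 2.7-fold higher number from compound 3 to compound 4 (0.43 log units; beyond the scatter), the opposite direction to a 2.4-fold lower number from compound 1 to compound 2 (0.39 log units; beyond the scatter). Losing the aromatic ring at this place therefore does not by itself set the direction of the change: 2-hydroxyethyl enters in one step and ethyl in the other, and the core of compound 3 is not the same as the core of compound 1, so either difference may matter. Nothing available here explains why the number rose.

The compounds shown leave open whether the opposite directions of the two steps trace to the hydroxyl of the 2-hydroxyethyl group or to the difference in the core, since these two differences occur together. A methoxyethyl or aminoethyl chain, or a chain ending in a carboxylic acid, at this place on the core of compound 3 would show how far the result depends on the particular group that enters.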